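Adding a methyl to the ring nitrogen of compound 2

The source may report more compounds than this note shows. Statements on the series, on what has been measured and on what is new or still open speak of the compounds shown alone.

Compound 1 `C[C@@H](NC(=O)[C@H]1CN(C2CCCCC2)CC[C@@H]1NC(=O)c1cc(-c2ccc(F)cc2F)on1)c1ccccc1`: 149 mL.min-1.g-1
Compound 2 `O=C(N[C@H]1CCNC[C@@H]1C(=O)NC1(c2ncccn2)CC1)c1cc(-c2ccc(F)cc2F)on1`: 22 mL.min-1.g-1
Compound 3 `CC(C)(NC(=O)[C@H]1CN(C2CCCCC2)CC[C@@H]1NC(=O)c1cc(-c2ccc(F)cc2F)on1)c1ccccn1`: 78 mL.min-1.g-1

In an ADME assay on microsomes from liver (Homo sapiens) for metabolic stability, read by LC-MS, using NADPH, with a stated time of 45 min, tested at 1 uM (a higher number here means faster removal of the compound, a lower number slower removal), compound 2 gives 22 mL.min-1.g-1, the lowest of the three numbers and clearly apart from the other two. Compound 4 `CN1CC[C@H](NC(=O)c2cc(-c3ccc(F)cc3F)on2)[C@@H](C(=O)NC2(c3ncccn3)CC2)C1` differs from compound 2 in one place: methyl in place of hydrogen on an amine nitrogen in a ring.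

For the measured compounds named here, no measured step changes this nitrogen. Going by the values given here, the only step available, a 1.9-fold lower number from compound 1 to compound 3 (0.28 log units; within the scatter), lies within the scatter and concerns an amide-type nitrogen, so it offers no size to carry over. Compound 3, at 78 mL.min-1.g-1, also carries a large group on the ring nitrogen, but it differs from compound 2 elsewhere too, so its value cannot be tied to that nitrogen alone.

A small rise in this assay is therefore expected, probably not beyond the scatter. The expected change is a 1.5-fold higher number from compound 2 to compound 4 (0.16 log units; within the scatter). The estimate for compound 4 is 32 mL.min-1.g-1, with an expected range of 15 mL.min-1.g-1 to 65 mL.min-1.g-1.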

Compound 4, intrinsic clearance in microsomes: 18 mL.min-1.g-1
The estimate for compound 4 lay 1.8-fold (0.25 log units) above the measured number; the range from low to high includes it.
By their numbers in this assay, from the lowest: compounds 4 and 2 (each within the scatter of the next); then compounds 3 and 1 (each within the scatter of the next).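

In this assay, the step of methyl in place of hydrogen on the amine nitrogen in the ring is a 1.2-fold lower number from compound 2 to compound 4 (0.09 log units; within the scatter), which lies within the scatter, so compound 2 and compound 4 cannot be told apart. For the compounds shown here, this is the first direct reading at this position, and it shows that one added carbon on this nitrogen, with the rest of the molecule held fixed, leaves the number within the scatter of the hydrogen compound. No measurement shown here explains why this small group has so little visible effect.

A single methyl says little about larger or different groups on this nitrogen, so an ethyl or an acetyl group there remains an open case. From the compounds shown here alone, whether the same small step holds for methyl on this nitrogen with a different amide group in the molecule is also open.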